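A 4-fluorophenyl swap on the shared core

The compounds below may be only part of what the source reports. "The series", "measured", "known", "first", "only" and "open" are said of these compounds alone.

Among the measured compounds shown here, in a toxicity assay on HepG2 2.2.15 cells (Homo sapiens) for cytotoxicity, read by CellTiter-Glo (on this read-out lower numbers stand for higher toxicity in this test and higher numbers for lower toxicity in this test), compound 1 (`O=C1OC(c2ccccc2)CN1c1cnn2c1CN(C(=O)Nc1cc(F)c(F)c(F)c1)C(C1CC1)C2`) gives 7410 nM, the middle of the three numbers measured so far. Compound 2 (`O=C1OC(c2ccc(F)cc2)CN1c1cnn2c1CN(C(=O)Nc1cc(F)c(F)c(F)c1)C(C1CC1)C2`) gives 3560 nM, and compound 3 (`CC1CN(C(=O)Nc2cc(F)c(F)c(F)c2)Cc2c(N3CC(C#N)CC3=O)cnn21`) gives 115000 nM. Compound 4 (`O=C(Nc1cc(F)c(F)c(F)c1)N1Cc2c(-c3ccc(F)cc3)cnn2CC1C1CC1`) has 4-fluorophenyl in place of 2-oxo-5-phenyl-1,3-oxazolidin-3-yl on an aromatic carbon. For the measured compounds named here, no measured step covers this exchange directly. The nearest one is modest: a 2.1-fold lower number from compound 1 to compound 2 (0.32 log units; beyond the scatter), with fluoro in place of hydrogen on an aromatic carbon. Going by the values given here, with that step as the only guide, no change clearly beyond the scatter is expected in this assay. The expected step is a 1.1-fold lower number from compound 1 to compound 4 (0.02 log units; within the scatter). For compound 4 the estimated value is 7000 nM, within an expected range of 2500 nM to 25000 nM.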

Compound 4, half-maximal cytotoxic concentration: 38500 nM
Beside the measured number, compound 4's estimate is 5.5-fold (0.74 log units) below it; the measured number lies above the stated range.
By their numbers in this assay, from the lowest: compound 2; then compound 1; then compound 4; then compound 3.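

Among the compounds shown here, at this aromatic carbon, the earlier compounds showed only a fluoro edit within the 2-oxo-5-phenyl-1,3-oxazolidin-3-yl group, whereas replacing that whole group with 4-fluorophenyl gives a 5.2-fold higher number from compound 1 to compound 4 (0.72 log units; beyond the scatter) in this assay. The group on this carbon therefore moves the read-out further than that fluoro edit did, here towards lower toxicity in this test. No available evidence accounts for this shift. The compounds shown do not separate the loss of the oxazolidinone ring from the gain of the directly attached aryl ring. As far as these compounds go, how an amine or a carboxylic acid on this carbon would read also remains open.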